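This account rests on a few compounds, and the source may have more. Where it says the series, first, only, none or still open, it means among the compounds named here.

Measured so far in an assay on isolated protein for binding affinity to Alpha-1B adrenergic receptor (Homo sapiens); a higher number here means a weaker inhibitor, a lower number a stronger inhibitor:
- compound 1 `O=S(=O)(c1ccc2cc[nH]c2c1)N1CCC[C@@H]1CCN1CCC(c2c[nH]c3ccccc23)CC1`: 1.29 nM
- compound 2 `O=S(=O)(c1ccc2cc[nH]c2c1)N1CCC[C@@H]1CCN1CCC(c2cc3ccccc3[nH]2)CC1`: 89.1 nM
- compound 3 `O=c1oc2ccccc2n1C1CCN(CC[C@H]2CCCN2S(=O)(=O)c2ccc3cc[nH]c3c2)CC1`: 309 nM

Compound 3 gives the highest number of the three; its nearest neighbour is compound 2 and its furthest is compound 1. The steps into compound 3 were a 240-fold higher number from compound 1 to compound 3 (2.38 log units; beyond the scatter) and a 3.5-fold higher number from compound 2 to compound 3 (0.54 log units; beyond the scatter), so the group on the saturated ring carbon moves this assay strongly.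

Compound 4 `O=C(c1ccc(F)cc1)C1CCN(CC[C@H]2CCCN2S(=O)(=O)c2ccc3cc[nH]c3c2)CC1` makes the change (a group of 9 heavy atoms (7 carbon, 1 oxygen, 1 fluorine; one six-membered aromatic ring of carbon only) in place of a group of 10 heavy atoms (7 carbon, 1 nitrogen, 2 oxygen; one five-membered aromatic ring with 2 hetero atoms, one six-membered aromatic ring of carbon only), on a saturated ring carbon). Among the compounds with values here, no measured step involves the (4-fluorophenyl)carbonyl group, so only the spread of the three values on that position offers guidance. Given that spread, a step in this assay back toward lower numbers is expected, of the size a 10-fold lower number from compound 3 to compound 4 (1.01 log units; beyond the scatter). For compound 4 the estimate is 30 nM, within 5 nM to 200 nM.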

Compound 4, inhibition constant: 19.1 nM
Compound 4: the middle estimate sits 1.6-fold (0.20 log units) above what was measured; the range from low to high includes it.
By their numbers in this assay, from the lowest: compound 1; then compound 4; then compound 2; then compound 3.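

On the saturated ring carbon, in this assay, the (4-fluorophenyl)carbonyl group, with one six-membered aromatic ring and no five-membered aromatic ring, gives a lower number than both bicyclic groups that had lost ground (a 16-fold lower number from compound 3 to compound 4 (1.21 log units; beyond the scatter); a 4.7-fold lower number from compound 2 to compound 4 (0.67 log units; beyond the scatter)). A fused five-membered aromatic ring is therefore not required for a lower number at this position, though 1H-indol-3-yl still holds the lowest number of the four (a 15-fold higher number from compound 1 to compound 4 (1.17 log units; beyond the scatter)). No measured evidence accounts for this order.

Open, as far as these compounds go, are the separate shares of the fluorine and the carbonyl in these steps. Also open, from the compounds shown here alone, is how a benzyl group or a primary amine on the same carbon would compare.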